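The source may hold more compounds than are shown below. What is called first, only, known or untested is meant among the compounds shown, and "the series" means these compounds.

Compound 1, `O=C1C(=O)N(CCCCn2cc(COc3cc(=O)oc4ccccc34)nn2)c2ccc(F)cc21`, in a functional assay on HCT-116 cells (Homo sapiens) for inhibition, read by sulforhodamine B assay, with a stated time of 48 h, tested at 50 uM (on this read-out lower numbers stand for less inhibition of growth and higher numbers for more inhibition of growth at the one concentration tested), gives 67%.
Compound 2, `COc1ccc2c(c1)C(=O)C(=O)N2CCCCCn1cc(COc2cc(=O)oc3ccccc23)nn1`, in this assay gives 25%.

For the measured compounds named here, compound 2 stands lowest of the two numbers measured so far. Its nearest neighbour, compound 1, gives a number higher by a margin that lies beyond the usual scatter of repeated measurements. Compound 1 differs from compound 2 in more than one place, so the two values show only that one sits well above the other; no single step can be read off between them.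

Compound 3, `O=C1C(=O)N(CCCCCn2cc(COc3cc(=O)oc4ccccc34)nn2)c2ccc(Br)cc21`, has not yet been measured. It differs from compound 2 in one place:

bromo in place of methoxy on an aromatic carbon

Going by the values given here, no step between measured compounds isolates this exchange, so the expectation rests on the two values alone. Among the compounds with values here, compound 2 with its methoxy gives 25%, and the only other compound, compound 1, gives 67%. On that thin basis, compound 3 is expected to move upward in this assay by a moderate step of a number 20 percentage points higher from compound 2 to compound 3 (beyond the scatter), though this expectation carries wide uncertainty. For compound 3 the estimated value is 45%, within a range from 15% to 75%.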

Compound 3, percent growth inhibition at one concentration: 43%
The estimate for compound 3 lay 2 percentage points above the measured number; the measured number falls inside the stated range.
By their numbers in this assay, from the lowest: compound 2; then compound 3; then compound 1.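

In this assay, for the compounds shown here, the exchange of methoxy for bromo on this aromatic carbon gives the first step that can be read in one place: a number 18 percentage points higher from compound 2 to compound 3 (beyond the scatter), a modest rise that lies beyond the usual scatter. The rest of the structure is shared by the pair, so this aromatic carbon of the core is not indifferent to what it carries: the number moves when methoxy, with its hydrogen-bond acceptor and two heavy atoms, leaves and the single bromine atom, with no hydrogen-bond acceptor, enters. No measurement at hand bears on the reason for this rise, so the step stands as an observation only.

A single pair cannot show whether the rise is particular to bromo, or how a chloro, a nitrile, an amine or a carboxylic acid on the same aromatic carbon would compare with these two groups. It also leaves open whether the same exchange would give a step of similar size on a compound with a shorter or a longer chain, or at another carbon of the same ring.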